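The compounds below may be only part of what the source reports. "The series", "measured", "known", "first", "only" and "open" are said of these compounds alone.

Measured in a functional assay on A549 cells (Homo sapiens) for cytotoxicity, read by MTT assay, with a stated time of 72 h; a higher number here means a weaker inhibitor, a lower number a stronger inhibitor:
compound 1 `CCOC(=O)c1c(C)oc2ncnc(Nc3cccc(C)c3)c12`: > 1000000 nM
compound 2 `Cc1cccc(Nc2ncnc3oc(C)c(CO)c23)c1`: 24000 nM
compound 3 `Cc1oc2ncnc(Nc3ccc(OCc4cccc(F)c4)c(Cl)c3)c2c1C(=O)O`: 21400 nM

Compound 1 gives only a limit and not a number: the limit of > 1000000 nM in this assay, at which 1 of the 3 values shown sits. Its position on the scale is therefore known only from one side.

Compound 4 `CCOC(=O)c1c(C)oc2ncnc(Nc3cccc(OC)c3)c12` keeps the core and the ethoxycarbonyl of compound 1 and alters one group, from 3-methylphenyl to 3-methoxyphenyl, with methoxy in place of methyl on an aromatic carbon.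

Among the measured compounds shown here, only one measured step starts from compound 1, and it lies elsewhere in the molecule. In an at least 41-fold lower number from compound 1 to compound 2 (1.61 log units; beyond the scatter), a large step beyond the scatter, hydroxymethyl takes the place of ethoxycarbonyl while the 3-methylphenyl stays unchanged. That step shows how much the ethoxycarbonyl position can matter in this assay, but it does not measure the swap made here. Compound 3 differs from compound 1 in more than one place, so it does not isolate this swap either.

Compound 4 retains the ethoxycarbonyl that an at least 41-fold lower number from compound 1 to compound 2 (1.61 log units; beyond the scatter) removes, so no step beyond the scatter is expected, and a report of only a limit is quite likely. The estimated step is a number no higher from compound 1 to compound 4 (the limit leaves the size open). For compound 4 the expected value is 1000000 nM, with an estimated range from 200000 nM to 2000000 nM.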

Compound 4, half-maximal inhibitory concentration: > 1000000 nM
Compound 4: no number, only a limit; the forecaster's own chance of this, stated with the estimate: 65%; the middle value lies on the limit itself.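

Compound 1 and compound 4 each give only a limit in this assay, not a number, so the step between them cannot be read: the limit of > 1000000 nM in this assay, at which 2 of the 4 values shown sit.

The compounds shown leave open whether methoxy in place of methyl on an aromatic carbon changes the result at all, and how far past that limit either compound lies.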